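Ethyl for methyl on the aminobenzimidazole core

The source may report more compounds than this note shows. Statements on the series, on what has been measured and on what is new or still open speak of the compounds shown alone.

Measured compounds:
compound 1 `CSc1nc2cccc(C(=O)O)c2n1Cc1ccc(-c2ccccc2-c2noc(O)n2)cc1`: 100%
compound 2 `CCSc1nc2cccc(C(=O)O)c2n1Cc1ccc(-c2ccccc2-c2noc(O)n2)cc1`: 83%
compound 3 `CNc1nc2cccc(C(=O)O)c2n1Cc1ccc(-c2ccccc2-c2noc(O)n2)cc1`: 14%

The study covers three measured compounds and one unmeasured analogue, compound 4 `CCNc1nc2cccc(C(=O)O)c2n1Cc1ccc(-c2ccccc2-c2noc(O)n2)cc1`, all tested or to be tested in a functional assay on the whole organism for inhibition, with Rattus norvegicus as the target, with a stated time of 3 h, at a dose of 1 mg/kg by the oral route; a lower number here means less inhibition, a higher number more inhibition at the dose given (going by the name of the read-out). In this assay compound 1 gives 100%, compound 2 gives 83% and compound 3 gives 14%.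

The change from compound 1 to compound 2 is methyl in place of hydrogen on a saturated chain carbon bound to a sulfur, and it produced a number 17 percentage points lower from compound 1 to compound 2 (beyond the scatter). The cores of compound 1 and compound 3 differ by methylamino in place of methylsulfanyl on an aromatic carbon, which went with a number 86 percentage points lower from compound 1 to compound 3 (beyond the scatter).

The change from compound 3 to compound 4 is methyl in place of hydrogen on a saturated chain carbon bound to a nitrogen on an aromatic ring. It is the same kind of change as from compound 1 to compound 2, but not the same: in the first case the place is on a saturated chain carbon bound to a sulfur, here it is on a saturated chain carbon bound to a nitrogen on an aromatic ring. Because the earlier step gave a number 17 percentage points lower from compound 1 to compound 2 (beyond the scatter), compound 4 is expected to show a number 4 percentage points lower from compound 3 to compound 4 (within the scatter), a small drop that cannot go far below the already low value of compound 3. The estimate for compound 4 is 10%, with a range expected from 0% to 28%.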

Compound 4, a percentage reported as inhibition, in the whole organism at one dose (the size of the read-out at that dose, not a potency): 25%
Compound 4: the middle estimate sits 15 percentage points below what was measured, and the stated range covers the measured number.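

On the core of compound 3, methyl in place of hydrogen gave a number 11 percentage points higher from compound 3 to compound 4 (beyond the scatter) in this assay, the opposite direction to the core of compound 1, so the change does not carry over unchanged from one core to the other: the same change on two cores in this assay, a number 17 percentage points lower (beyond the scatter) from compound 1 to compound 2 and a number 11 percentage points higher (beyond the scatter) from compound 3 to compound 4, 28 percentage points apart, beyond the scatter of two such steps. The exchange of sulfur-linked for nitrogen-linked groups remains the larger effect, with ethylamino in place of ethylsulfanyl giving a number 58 percentage points lower from compound 2 to compound 4 (beyond the scatter) and ethylamino in place of methylsulfanyl giving a number 75 percentage points lower from compound 1 to compound 4 (beyond the scatter). These steps show that the outcome of this one small change depends on the core at a single dose and time, but they do not show why, nor how it would behave on any further core.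

The compounds shown leave open whether a longer chain such as propyl, on the sulfur or on the nitrogen, would follow either direction. They also leave open how a methoxy group in place of methylsulfanyl would stand.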